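Chain extension at the ring nitrogen: compound 3 expected

A few compounds are considered here, and "the series" means these few. Any claim that something is new, unique, unknown or untested is made for them only; others in the source may bear on it.

Compound 2 `O=c1c2ccccc2c(-c2cccnc2)nn1CCO` stands lowest of the two numbers in hand: in an assay on isolated protein (Oryctolagus cuniculus) with Thromboxane-A synthase (Homo sapiens) as the target, tested at 1 uM (a higher number here means more inhibition at the concentration tested (going by the name of the read-out), a lower number less inhibition), compound 2 gives 69%, whereas compound 1 `CCCCCCCCn1nc(-c2cccnc2)c2ccccc2c1=O` gives 99%. Among the measured compounds shown here, the one measured step, a number 30 percentage points lower from compound 1 to compound 2 (beyond the scatter), shows that shortening the chain on the ring nitrogen to a hydroxy-ended two-carbon unit costs a modest but real amount of inhibition. Compound 3 `CC(C)NC(=O)CCCn1nc(-c2cccnc2)c2ccccc2c1=O` reverses that direction: (isopropylcarbamoyl)methyl in place of hydroxy on a saturated chain carbon, two bonds along the chain from an aromatic nitrogen. The change restores chain length beyond the hydroxy of compound 2, though with an amide rather than the plain hexyl of compound 1, so the step from compound 1 to compound 2 bears on it only as a partial analogy. A gain is therefore expected, probably smaller than a full return to compound 1. For compound 3 in this assay the estimate is 85% (62% to 99%), an expected step of a number 16 percentage points higher from compound 2 to compound 3 (beyond the scatter).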

Compound 3, a percentage reported as inhibition, at one concentration (the size of the read-out at that concentration, not a potency): 89%
Beside the measured number, compound 3's estimate is 4 percentage points below it, within the range that was stated.
By their numbers in this assay, from the lowest: compound 2; then compounds 3 and 1 (each within the scatter of the next).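

In this assay, (isopropylcarbamoyl)methyl in place of hydroxy gives a number 20 percentage points higher from compound 2 to compound 3 (beyond the scatter) and so shows that the lower number of compound 2 is not a fixed feature of the shared core: this position can carry a longer chain ending in an amide and give a higher number. Isopropylcarbamoyl in place of pentyl gives a number 10 percentage points lower from compound 1 to compound 3 (within the scatter) and so shows that, in this assay, the amide-bearing chain cannot be told apart from the all-carbon chain of compound 1. Nothing on hand accounts for either step.

Still open, as far as these compounds go, is whether the step up from compound 2 follows from the amide or from chain length alone. A carboxylic acid or a dimethylamino group at the end of the same chain would test how far the chain end can vary.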